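The compounds below may be only part of what the source reports. "The series", "measured", "known", "first", "only" and "open" are said of these compounds alone.

Measured so far:

compound 1, `ClCc1ccc(Cn2cnc3c(Cl)ncnc32)cc1` — 26900 nM
compound 2, `Nc1nc(Cl)c2ncn(Cc3ccccc3CCl)c2n1` — 44700 nM
compound 3, `ClCc1cccc(Cn2cnc3nc(Cl)nc(Cl)c32)c1` — 2810 nM

All three were tested in a functional assay on A498 cells (Homo sapiens) for cytotoxicity, read by sulforhodamine B assay, with a stated time of 48 h; a lower number here means a stronger inhibitor of growth, a higher number a weaker inhibitor of growth. Compound 1 stands second highest of the three numbers. Its nearest neighbour is compound 2, whose number lies within the usual scatter of compound 1, so the two cannot be told apart. Within the data shown here, compound 3 stands furthest away, with a number well below that of compound 1, beyond the scatter; compound 3 differs from compound 1 in more than one place, so no single step can be drawn between them.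

The compound not yet measured is compound 4, `ClCc1ccc(Cn2cnc3c(Cl)nc(Cl)nc32)cc1`. It differs from compound 1 in one place: chloro in place of hydrogen on an aromatic carbon. Among the measured compounds shown here, no pair of measured compounds isolates this change, so nothing measured fixes its size. Since compound 3, which also carries two chloro groups on the shared core, gives 2810 nM, compound 4 is expected to move in the same direction, toward a lower number, and the expected step of a 5.4-fold lower number from compound 1 to compound 4 (0.73 log units; beyond the scatter) is taken as beyond the scatter. Compound 4 is thus estimated at 5000 nM, with a range from 1500 nM to 17000 nM.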

Compound 4, concentration for total growth inhibition: 25100 nM
Compound 4: the middle estimate sits 5.0-fold (0.70 log units) below what was measured, and the stated range ends below it.
By their numbers in this assay, from the lowest: compound 3; then compounds 4, 1 and 2 (each within the scatter of the next).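

Within this assay, putting chloro in place of hydrogen on the aromatic carbon between two ring nitrogen atoms gives a 1.1-fold lower number from compound 1 to compound 4 (0.03 log units; within the scatter), so compound 1 and compound 4 cannot be told apart. Among these compounds, this is the first step measured at this position, and it shows that on the core of compound 1 this single chloro makes no difference that the assay can detect. No measurement on hand offers a reason for this result.

From the compounds shown here alone, it remains open whether a different group at this position, such as methoxy, a nitrile or a carboxylic acid, would also leave the number within the scatter. Nor do these compounds show whether the same chloro change would read the same way in a compound that differs from compound 1 elsewhere.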